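The source may report more compounds than this note shows. Statements on the series, on what has been measured and on what is new or still open speak of the compounds shown alone.

Among the measured compounds shown here, in an ADME assay on liver for metabolic stability, with Liver microsome (Rattus norvegicus) as the target, read by LC-MS, using microsomes, with a stated time of 5 h (on this read-out higher numbers stand for fast clearance and lower numbers for slow clearance), compound 1 `C[C@]1(O)C[C@](c2cccc(OC(F)(F)F)c2)([C@H](O)c2ccccn2)C1` gives 50 mL/min/kg, the lower of the two numbers so far, while compound 2 `O[C@H](c1ccccn1)[C@]1(c2cccc(OC(F)(F)F)c2)C[C@H](O)C1` gives 117 mL/min/kg. Compound 3 `C[C@]1(O)C[C@](c2cccc(C(F)(F)F)c2)([C@H](O)c2ccccn2)C1` keeps the core of compound 1 and alters one group: trifluoromethyl in place of trifluoromethoxy on an aromatic carbon. For the measured compounds named here, the only measured step, a 2.3-fold higher number from compound 1 to compound 2 (0.37 log units; beyond the scatter), is modest and concerns a saturated ring carbon, not this aromatic carbon, so no measured step tests this change directly. No step beyond the scatter is therefore expected in this assay. The expected size is a 1.1-fold lower number from compound 1 to compound 3 (0.05 log units; within the scatter). For compound 3 the estimated value is 45 mL/min/kg, with an expected range of 25 mL/min/kg to 85 mL/min/kg.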

Compound 3, clearance: 66.7 mL/min/kg
The estimate for compound 3 lay 1.5-fold (0.17 log units) below the measured number, and the stated range covers the measured number.
By their numbers in this assay, from the lowest: compounds 1, 3 and 2 (each within the scatter of the next, the first and the last beyond it).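

In this assay, putting trifluoromethyl in place of trifluoromethoxy on the aromatic carbon gives a 1.3-fold higher number from compound 1 to compound 3 (0.13 log units; within the scatter), so removing the oxygen from this group leaves clearance within the usual scatter. Among the compounds shown here, the earlier step tested only a saturated ring carbon, so this is the first reading of a change on the aromatic ring. No measurement here offers an explanation for this result.

From the compounds shown here alone, whether an amine, a carboxylic acid or a longer chain at this aromatic carbon would shift clearance remains open. So does whether the same swap would behave alike in compound 2.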